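Trimming the Side Chain of Compound 1

The compounds below may be only part of what the source reports. "The series", "measured", "known", "first", "only" and "open" are said of these compounds alone.

Compound 1 `CC(C)CC1(Cc2ccccc2)OS(=O)(=O)C=C1OCc1ccccc1`: in an ADME assay on HEL cells (Homo sapiens) for cytotoxicity, with a stated time of 3 days (a higher number here means that more compound is tolerated, a lower number that less compound is tolerated), compound 1 gives 102000 nM.
Compound 2 `CCC1(Cc2ccccc2)OS(=O)(=O)C=C1OC(c1ccccc1)c1ccccc1`: in this assay compound 2 gives > 200000 nM, a limit of the assay rather than a number.
Compound 3 `CCC1(Cc2ccccc2)OS(=O)(=O)C=C1OCc1ccc(Cl)cc1`: in this assay compound 3 gives > 200000 nM, also a limit of the assay.

Going by the values given here, compound 1 thus holds the only actual number in this assay; the other two values sit at the limit of > 200000 nM in this assay, at which 2 of the 3 values shown sit. Compound 4 `CC1(Cc2ccccc2)OS(=O)(=O)C=C1OCc1ccccc1` differs from compound 1 by hydrogen in place of isopropyl on a saturated chain carbon bound to a saturated ring carbon, the same difference read one bond further out being isobutyl to methyl. Among the compounds with values here, no step between measured compounds is available to weigh such a change, so the expectation rests on compound 1 alone. The step of a 1.5-fold higher number from compound 1 to compound 4 (0.17 log units; within the scatter) is expected to stay within the usual scatter, leaning if anything toward more compound tolerated. Compound 4 is estimated at 150000 nM, in the range 60000 nM to 300000 nM.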

Compound 4, half-maximal cytotoxic concentration: 68000 nM
Estimate against measurement, compound 4: 2.2-fold (0.34 log units) above; measured number inside the range.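

Going by these compounds alone, the step of a 1.5-fold lower number from compound 1 to compound 4 (0.18 log units; within the scatter) is the first that can be read at this position, and in this assay it places hydrogen in the room of isopropyl, cutting isobutyl down to methyl. Removing that much of the side chain leaves compound 4 indistinguishable from compound 1. Steps to the other compounds cannot be read, since those values are limits of the assay and not numbers: the limit of > 200000 nM in this assay, at which 2 of the 4 values shown sit.

Still open, going by these compounds, is how the number would respond if an amine or a carboxylic acid stood in place of the isobutyl. A longer chain there is equally untested by these compounds.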